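Sulfonyl substitution in a shared aryl-acetylene acid core

The compounds below may be only part of what the source reports. "The series", "measured", "known", "first", "only" and "open" are said of these compounds alone.

Measured so far in an assay on CHO cells for displacement of a labelled ligand from prostaglandin D2 receptor 2 (Homo sapiens), read by scintillation counting; on this read-out lower numbers stand for stronger inhibition and higher numbers for weaker inhibition:
- compound 1 `CNS(=O)(=O)c1ccc(C)c(C#Cc2cc(Cl)ccc2OCC(=O)O)c1`: 10 nM
- compound 2 `CN(C)S(=O)(=O)c1cccc(C#Cc2cc(Cl)ccc2OCC(=O)O)c1`: 14 nM
- compound 3 `COCc1ccc(C#Cc2cc(Cl)ccc2OCC(=O)O)c(F)c1`: 22 nM

Compound 1 gives the lowest number of the three in this assay. Compound 2 stands within the usual scatter of compound 1, so no order between these two can be read from the data. Compound 3 lies beyond the scatter of compound 1, giving a higher number, so compound 1 is the stronger of that pair.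

Compound 4 `Cc1ccc(S(=O)(=O)N2CCCCC2C)cc1C#Cc1cc(Cl)ccc1OCC(=O)O` has not yet been measured in this assay. It differs from compound 1 in a single place: 2-methylpiperidin-1-yl in place of methylamino on a sulfonyl sulfur. The change replaces a group that carries a hydrogen-bond donor with a ring that carries none, while leaving the rest of the core untouched. Among the compounds with values here, no step between measured compounds matches this change directly, so no measured size is available for it.

A small step is expected, with the number at most modestly higher, because compound 2 gives 14 nM. The step from compound 1 to compound 4 is estimated at a 1.6-fold higher number from compound 1 to compound 4 (0.20 log units; within the scatter). Compound 4 is estimated at 16 nM in this assay, with a range from 5 nM to 50 nM.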

Compound 4, inhibition constant: 1.9 nM
For compound 4 the middle estimate is 8.4-fold (0.93 log units) above the measured one; measured number below the stated range.
By their numbers in this assay, from the lowest: compound 4; then compounds 1, 2 and 3 (each within the scatter of the next, the first and the last beyond it).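

In this assay, within the data shown here, the sulfonyl sulfur of the core of compound 1 accepts much more than a small amine: 2-methylpiperidin-1-yl in place of methylamino gives a 5.3-fold lower number from compound 1 to compound 4 (0.72 log units; beyond the scatter) and is the first step that can be read at this position. The hydrogen-bond donor of methylamino is therefore not required for strong inhibition on this core, and a six-membered non-aromatic ring on the sulfonyl sulfur goes with a clearly lower number. Nothing measured here accounts for the size of this step, which stands as an observation only.

The step changes several things at once, so the contributions of the ring, its methyl group and the loss of the donor remain unseparated. A plain piperidin-1-yl or a dimethylamino group on the core of compound 1 would help to divide them, while a morpholin-4-yl ring would test whether a ring oxygen is accepted at the same place.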